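A few compounds are considered here, and "the series" means these few. Any claim that something is new, unique, unknown or untested is made for them only; others in the source may bear on it.

Three compounds of this series carry a substituent on an aromatic nitrogen of a shared core. In a functional assay on COLO 205 cells (Homo sapiens) for cytotoxicity (on this read-out lower numbers stand for stronger inhibition and higher numbers for weaker inhibition), compound 1 `O=c1c2ccccc2c(Nc2n[nH]c3ccccc23)nn1-c1ccccc1` gives "not determined" (no result reported). In this assay compound 3 `Cc1cc(Nc2nn(Cc3ccc([N+](=O)[O-])cc3)c(=O)c3ccccc23)n[nH]1` gives "not determined" (no result reported). Among the measured compounds shown here, compound 2 `Cc1cc(Nc2nn(Cc3cccnc3)c(=O)c3ccccc23)n[nH]1` is the only one with a number: in this assay compound 2 gives 4100 nM, so it stands alone, with nothing to set beside it. Compound 4 `Cc1cc(Nc2nn(-c3ccc(F)cc3)c(=O)c3ccccc23)n[nH]1` has not yet been measured. It differs from compound 2 in one place: 4-fluorophenyl in place of (pyridin-3-yl)methyl on an aromatic nitrogen. For the measured compounds named here, no step between two measured compounds is known, and the data therefore say nothing about how much such an exchange on the aromatic nitrogen is worth. The change is expected to move the read-out little, if at all, beyond the usual scatter, in either direction. Compound 4 is estimated at 3000 nM in this assay, with a range from 800 nM to 12000 nM. The step thereby expected is a 1.4-fold lower number from compound 2 to compound 4 (0.14 log units; within the scatter), which stays within the scatter.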

Compound 4, half-maximal inhibitory concentration: 1600 nM
Compound 4: middle estimate off by 1.9-fold (0.27 log units), on the high side; the range from low to high includes it.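

The exchange on the aromatic nitrogen now has a measured size: in this assay, 4-fluorophenyl in place of (pyridin-3-yl)methyl gives a 2.6-fold lower number from compound 2 to compound 4 (0.41 log units; beyond the scatter), a modest change. The earlier compounds shown here could not show that this position responds at all, and here it does so between two groups with the same count of heavy atoms, each holding one six-membered aromatic ring. No measurement shown here accounts for the step.

The exchange alters the ring nitrogen, the fluorine and the carbon link together, so the compounds shown leave open which of these matters, and a 4-fluorobenzyl group or an unsubstituted phenyl group on the same nitrogen of this methylpyrazole series would begin to separate them. Steps involving compound 1 and compound 3 cannot be read.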